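The compounds below may be only part of what the source reports. "The series", "measured", "known", "first", "only" and "open" are said of these compounds alone.

Series notes. Compound 1 `CN(C)CCN1CCN(CC(=O)Nc2ccc(-c3nc4cc(Cl)ccc4o3)cc2)CC1`, compound 2 `Cc1cc(-c2nc3cc(Cl)ccc3o2)ccc1NC(=O)CN1CCN(CCN(C)C)CC1` and compound 3 `Cc1cc(-c2nc3ccccc3o2)ccc1NC(=O)CN1CCN(CCCN(C)C)CC1` have been run in an ADME assay on NIH3T3 cells (Mus musculus) for cytotoxicity, read by MTT assay, with a stated time of 24 h; on this read-out lower numbers stand for stronger inhibition and higher numbers for weaker inhibition. In this assay compound 1 gives 28700 nM, compound 2 gives 19200 nM and compound 3 gives 33500 nM; the three numbers lie within the scatter of one another, so no order among them is drawn. Going by the values given here, the one matched step so far, (hydrogen in place of methyl on an aromatic carbon), gave a 1.5-fold higher number from compound 2 to compound 1 (0.17 log units; within the scatter). The cores of compound 2 and compound 3 differ, but that difference is not broken down here.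

Compound 4 `CN(C)CCCN1CCN(CC(=O)Nc2ccc(-c3nc4ccccc4o3)cc2)CC1` is still to be measured in this assay. It differs from compound 3 by hydrogen in place of methyl on an aromatic carbon. Among the compounds with values here, this is the same kind of change as the one from compound 2 to compound 1, with one difference around the place: in compound 3 the carbon is meta to a 1,3-benzoxazol-2-yl group (9 heavy atoms), whereas in compound 2 it is meta to a 5-chloro-1,3-benzoxazol-2-yl group. Within the data shown here, compound 4 is expected to show a 1.2-fold higher number from compound 3 to compound 4 (0.08 log units; within the scatter), because the single earlier step of this kind gave a 1.5-fold higher number from compound 2 to compound 1 (0.17 log units; within the scatter). Compound 4 is therefore estimated at 40000 nM, with a range from 20000 nM to 80000 nM.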

Compound 4, half-maximal inhibitory concentration: 16700 nM
For compound 4 the middle estimate is 2.4-fold (0.38 log units) above the measured one, and the stated range ends above it.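

In this assay, hydrogen in place of methyl on an aromatic carbon, meta to a 1,3-benzoxazol-2-yl group, gives a 2.0-fold lower number from compound 3 to compound 4 (0.30 log units; within the scatter). Each step alone stays within the scatter, but set side by side they show that the change does not carry from one core to the other as a single fixed step: the same change on two cores in this assay, a 1.5-fold higher number (0.17 log units; within the scatter) from compound 2 to compound 1 and a 2.0-fold lower number (0.30 log units; within the scatter) from compound 3 to compound 4, 3.0-fold (0.48 log units) apart, beyond the scatter of two such steps. This does not show which difference between the two cores goes with the gap, since they differ in more than one place, nor does it give the size of the change on any third core.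

Open, as far as these compounds go, is whether the gap follows the chlorine on the benzoxazole or the length of the dimethylamino chain, which a matched pair on a core differing in only one of these places would separate. Also open, from the compounds shown here alone, is how an ethyl group or a fluorine at the same aromatic carbon would compare with the methyl and the hydrogen on these cores.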